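The source may report more compounds than this note shows. Statements on the series, on what has been measured and on what is new or still open speak of the compounds shown alone.

Compound 1, `Cn1cc(/C=C2/C(=O)Nc3ccccc32)c2cc(Nc3nccc(-c4ccccc4)n3)ccc21`, gives 14100 nM in a functional assay on U-87MG ATCC cells (Homo sapiens) for cytotoxicity, read by MTT assay, with a stated time of 48 h; on this read-out higher numbers stand for weaker inhibition and lower numbers for stronger inhibition.
Compound 2, `Cn1cc(/C=C2/C(=O)Nc3ccccc32)c2cc(Nc3nccc(-c4ccc(O)cc4)n3)ccc21`, gives 13200 nM in this assay.
Compound 3, `Cn1cc(/C=C2/C(=O)Nc3ccccc32)c2cc(Nc3nccc(-c4ccc(Cl)cc4)n3)ccc21`, gives 5820 nM in this assay.

Among these three, compound 3 has the lowest number: the step of a 2.4-fold lower number from compound 1 to compound 3 (0.38 log units; beyond the scatter) and the step of a 2.3-fold lower number from compound 2 to compound 3 (0.36 log units; beyond the scatter) both lie beyond the scatter, while the step of a 1.1-fold lower number from compound 1 to compound 2 (0.03 log units; within the scatter) does not. Compound 4, `Cn1cc(/C=C2/C(=O)Nc3ccccc32)c2cc(Nc3nccc(-c4ccc(F)cc4)n3)ccc21`, is so far unmeasured. It differs from compound 3 in one place: fluoro in place of chloro on an aromatic carbon, para to a large group.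

Two of the measured steps bear on this change, since they show what happens when the same aromatic carbon carries hydrogen, hydroxy or chloro. Putting chloro there, in the step of a 2.4-fold lower number from compound 1 to compound 3 (0.38 log units; beyond the scatter), lowered the number modestly, while hydroxy, in the step of a 1.1-fold lower number from compound 1 to compound 2 (0.03 log units; within the scatter), made no difference beyond the scatter. A fluoro group has not been tried here, so its effect in this assay is expected to fall between those of hydrogen and chloro: a small rise in the number from compound 3, near the edge of the scatter. For compound 4 the expected result is 9000 nM, with a range of 4500 nM to 18000 nM, which means an expected step of a 1.5-fold higher number from compound 3 to compound 4 (0.19 log units; within the scatter).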

Compound 4, half-maximal inhibitory concentration: 16400 nM
Compound 4: middle estimate off by 1.8-fold (0.26 log units), on the low side; the range from low to high includes it.
By their numbers in this assay, from the lowest: compound 3; then compounds 2, 1 and 4 (each within the scatter of the next).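

In this assay, the change from 4-chlorophenyl to 4-fluorophenyl gives a 2.8-fold higher number from compound 3 to compound 4 (0.45 log units; beyond the scatter) and so shows that the two halogens are not interchangeable at this position. Fluoro also gives a 1.2-fold higher number from compound 2 to compound 4 (0.09 log units; within the scatter) and a 1.2-fold higher number from compound 1 to compound 4 (0.07 log units; within the scatter), both within the scatter, so among the four groups shown on this carbon only chloro sets its compound apart. Nothing given here accounts for this difference between chloro and fluoro.

A bromo, methyl or trifluoromethyl group on this carbon would help show whether the lower number belongs to chloro alone. The compounds shown also leave open whether chloro would give the same result elsewhere on this ring, and whether an amine or a carboxylic acid here would match hydrogen or chloro.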